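The compounds below may be only part of what the source reports. "The series", "measured", "known", "first", "only" and "open" are said of these compounds alone.

In a functional assay for activation of Alpha-1A adrenergic receptor (Homo sapiens) (a higher number here means that more compound is needed for the effect, a lower number that less compound is needed), compound 1 `CS(=O)(=O)c1ccccc1NCc1c[nH]cn1` gives 126 nM. Compound 2 `c1ccc(-c2ccccc2OCc2c[nH]cn2)cc1` gives 15.9 nM in this assay, so compound 1 holds the higher of the two numbers, and the gap between them lies beyond the usual scatter. For compound 3 `CCN(CC)C(=O)c1ccccc1OCc1c[nH]cn1` the assay returns only a limit, < 100000 nM, which is the limit of < 100000 nM in this assay, at which 1 of the 3 values shown sits. Compound 4 `c1ccc(N2CCCCC2)c(NCc2c[nH]cn2)c1` has not yet been measured. It differs from compound 1 by piperidin-1-yl in place of methylsulfonyl on an aromatic carbon, on an aromatic carbon ortho to a group of 7 heavy atoms. Going by the values given here, no measured pair shows this change, so the step from compound 1 to compound 4 is only an expectation, set at a 2.1-fold lower number from compound 1 to compound 4 (0.32 log units; beyond the scatter) toward a lower number. Compound 4 is accordingly estimated at 60 nM, with a range from 10 nM to 400 nM.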

Compound 4, half-maximal effective concentration: 50.1 nM
Compound 4: middle estimate off by 1.2-fold (0.08 log units), on the high side; the measured number falls inside the stated range.
By their numbers in this assay, from the lowest: compound 2; then compound 4; then compound 1.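

In this assay, going by these compounds alone, the pair gives the only direct reading of this position, with a 2.5-fold lower number from compound 1 to compound 4 (0.40 log units; beyond the scatter) when piperidin-1-yl replaces methylsulfonyl on this aromatic carbon. The change is modest, so activation survives the swap of a group with two double bonds outside aromatic rings for a six-membered non-aromatic ring with a single nitrogen. Nothing measured here accounts for the size or direction of this step.

From the compounds shown here alone, how a morpholine, a pyrrolidine or a simple primary amine on this aromatic carbon would read remains open. A single pair also cannot show whether the step would hold on any other core.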